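Swapping methoxy for chloro on compound 2

The source may report more compounds than this note shows. Statements on the series, on what has been measured and on what is new or still open speak of the compounds shown alone.

Of the compounds shown here, two sharing one core have been measured so far. In a functional assay on HeLa cells (Homo sapiens) for cytotoxicity, read by MTT assay, with a stated time of 24 h (a higher number here means a weaker inhibitor, a lower number a stronger inhibitor), compound 1 (`O=c1nc2ccc(Br)cn2cc1Cc1ccc(Br)cc1`) gives 931000 nM. In this assay compound 2 (`COc1ccc(Cc2cn3cc(Br)ccc3nc2=O)cc1`) gives 928000 nM, which stands level with compound 1 within the usual scatter of repeated measurements.

Compound 3 (`O=c1nc2ccc(Br)cn2cc1Cc1ccc(Cl)cc1`) has not yet been measured. It keeps the core of compound 2 and changes one group: chloro in place of methoxy on an aromatic carbon, para to a large group (chloro in place of methoxy on an aromatic carbon).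

For the measured compounds named here, only one measured step bears on this change. It is a 1.0-fold lower number from compound 1 to compound 2 (0.00 log units; within the scatter), where methoxy took the place of bromo on the same ring carbon, and it stays within the scatter. Going by the values given here, no chloro compound has been measured yet, but compound 3 differs from compound 1 only in having chloro where compound 1 has bromo. No change beyond the scatter is therefore expected in this assay, in either direction.

The expected step is a 1.0-fold lower number from compound 2 to compound 3 (0.01 log units; within the scatter). Compound 3 is estimated at 900000 nM, with an expected range from 500000 nM to 1600000 nM.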

Compound 3, half-maximal inhibitory concentration: > 1000000 nM
Compound 3: a limit, no number; the forecaster's own chance of this, stated with the estimate: 10%; middle value at least 1.1-fold (0.04 log units) from the limit.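

In this assay, compound 3 gives a limit of the assay and not a number: the limit of > 1000000 nM in this assay, at which 1 of the 3 values shown sits.

Only a floor can therefore be read for each step to this compound, with an at least 1.0-fold higher number from compound 2 to compound 3 (0.03 log units; that floor lies within the scatter) when chloro replaces methoxy, and an at least 1.0-fold higher number from compound 1 to compound 3 (0.03 log units; that floor lies within the scatter) when chloro replaces bromo. What this adds is a third group on the aromatic carbon para to a large group: with methoxy, bromo and chloro now tried there, no step among the three compounds is shown to go beyond the scatter, and chloro gives no sign of a lower number.

On these data alone, how far past the limit compound 3 truly lies stays unknown, so it could sit level with compound 1 and compound 2 or well away from them. Also open, as far as these compounds go, is whether a quite different group at this position, such as an amine or a carboxylic acid, would bring the number down in this assay.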